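The source may hold more compounds than are shown below. What is called first, only, known or untested is meant among the compounds shown, and "the series" means these compounds.

Going by the values given here, in an ADME assay on microsomes from liver (Homo sapiens) for pharmacokinetics, read by LC-MS, using NADPH, with a stated time of 30 min, tested at 1 uM (on this read-out lower numbers stand for slow clearance and higher numbers for fast clearance), compound 1 `CC[C@H]1CC[C@H](C2=NC3(CCN(S(=O)(=O)CCc4c(C)cc(N(C)C(N)=O)cc4C)CC3)C(=O)N2)CC1` gives 170 mL.min-1.g-1 and compound 2 `Cc1cc(N(C)C(N)=O)cc(C)c1CCS(=O)(=O)N1CCC2(CC1)N=C(c1ccc(OC(F)(F)F)cc1)NC2=O` gives 48 mL.min-1.g-1, the lower of the two numbers measured so far. Among the compounds with values here, the only measured step is a 3.5-fold lower number from compound 1 to compound 2 (0.55 log units; beyond the scatter), a modest one, in which 4-(trifluoromethoxy)phenyl takes the place of 4-ethylcyclohexyl. Compound 3 `Cc1cc(N2C(=O)NC(=O)C2C)cc(C)c1CCS(=O)(=O)N1CCC2(CC1)N=C(c1ccc(OC(F)(F)F)cc1)NC2=O` keeps the 4-(trifluoromethoxy)phenyl group of compound 2 and changes another place: 5-methyl-2,4-dioxoimidazolidin-1-yl in place of carbamoyl(methyl)amino on an aromatic carbon. There, 5-methyl-2,4-dioxoimidazolidin-1-yl replaces carbamoyl(methyl)amino on an aromatic carbon. The measured step concerns a different place and gives no direct guide to the size of this change, so no shift beyond the scatter is expected in this assay, in either direction. The expected change is a 1.1-fold lower number from compound 2 to compound 3 (0.03 log units; within the scatter). With compound 2 at 48 mL.min-1.g-1 as the starting point, the estimate for compound 3 is 45 mL.min-1.g-1, with an expected range from 18 mL.min-1.g-1 to 110 mL.min-1.g-1.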

Compound 3, intrinsic clearance in microsomes: 71 mL.min-1.g-1
Beside the measured number, compound 3's estimate is 1.6-fold (0.20 log units) below it; the measured number falls inside the stated range.
By their numbers in this assay, from the lowest: compounds 2 and 3 (each within the scatter of the next); then compound 1.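

In this assay, going by these compounds alone, this is the first reading at the aromatic carbon meta to two methyl groups, since the earlier step concerned a different place: the change gives a 1.5-fold higher number from compound 2 to compound 3 (0.17 log units; within the scatter) and so stays inside the usual spread of repeats. At this position, with 4-(trifluoromethoxy)phenyl held constant, carbamoyl(methyl)amino, which has no ring, can therefore give way to a group carrying a five-membered non-aromatic ring with no shift in clearance beyond the scatter. No supporting measurement is available to explain this result.

The compounds shown leave open how a simple amine, a carboxylic acid or the 2,4-dioxoimidazolidin-1-yl ring without its methyl group would read at this aromatic carbon. They also leave open whether 5-methyl-2,4-dioxoimidazolidin-1-yl would behave the same way in a compound carrying 4-ethylcyclohexyl.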